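Pentylselanyl to methylsulfanyl on the aminoquinazoline core

A few compounds are considered here, and "the series" means these few. Any claim that something is new, unique, unknown or untested is made for them only; others in the source may bear on it.

The measured compounds:
compound 1, `CCCCC[Se]c1nc(N)c2ccccc2n1`, > 100000 nM;
compound 2, `CCCCC[Se]c1nc(NCc2ccccc2)c2ccccc2n1`, > 100000 nM;
compound 3, `CCCCC[Se]c1nc(NCc2ccc(SC)cc2)c2ccccc2n1`, > 100000 nM.

In a functional assay on HT-29 cells (Homo sapiens) for cytotoxicity, read by MTT assay, with a stated time of 72 h (on this read-out lower numbers stand for higher toxicity in this test and higher numbers for lower toxicity in this test), compound 1 gives > 100000 nM, which is a limit of the test and not a number. In this assay compound 2 gives > 100000 nM, again a limit. In this assay compound 3 gives > 100000 nM, also a limit. Compound 2 therefore stands at the limit, as do the two others shown, and the step that the two limits leave unreadable from compound 1 to compound 2 and the step that the two limits leave unreadable from compound 2 to compound 3 are both unreadable for this reason.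

Compound 4, `CSc1nc(NCc2ccccc2)c2ccccc2n1`, is not yet measured. It differs from compound 2 as follows: a group of 2 heavy atoms (1 carbon, 1 sulfur; no ring) in place of a group of 6 heavy atoms (5 carbon, 1 selenium; no ring), on an aromatic carbon. The entering methylsulfanyl sits on an aromatic carbon of a six-membered aromatic ring with 2 nitrogen, between two ring nitrogen atoms.

Within the data shown here, no measured step bears on this change, because the limit of > 100000 nM in this assay, at which 3 of the 3 values shown sit, leaves every step within the shared core unreadable. The estimated step from compound 2 to compound 4 is therefore a step that the limit leaves unreadable from compound 2 to compound 4, with no direction beyond the scatter expected. Compound 4 is expected to give 150000 nM, within 40000 nM to 600000 nM, most likely reported again as a limit.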

Compound 4, concentration lethal to 50% of the cells: > 100000 nM
Compound 4: only a limit was reported (the forecaster's own chance of this, stated with the estimate: 75%); the middle value lies beyond the limit too.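

In this assay compound 4 gives > 100000 nM, which is a limit and not a number. Compound 2 also stands at a limit, so the step from compound 2 to compound 4 cannot be read: the limit of > 100000 nM in this assay, at which 4 of the 4 values shown sit.

The compounds shown leave open whether any change on the shared core yields a measurable value in this assay.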